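Swapping a Saturated Ring for a Fluorinated Aromatic Ring

The compounds below may be only part of what the source reports. "The series", "measured", "known", "first", "only" and "open" are said of these compounds alone.

Measured so far in an assay on TT cells for inhibition of proto-oncogene tyrosine-protein kinase receptor Ret variant C634W (Homo sapiens), read by MTT assay, with a stated time of 10 days; on this read-out lower numbers stand for stronger inhibition of growth and higher numbers for weaker inhibition of growth:
Compound 1 `CC(C)n1nc(-c2cc(C3CCCCC3)on2)c2c(N)ncnc21` reaches only the assay limit, > 10000 nM.
Compound 2 `CCCCCCCn1nc(-c2cc(C3CC3)on2)c2c(N)ncnc21` likewise stops at the limit, > 10000 nM.
Compound 3 `CC(C)n1nc(/C=N/OCc2ccccc2)c2c(N)ncnc21` gives 9270 nM.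

Compound 1 thus stands at the edge of what this assay can report: its result is a limit rather than a number, and (the limit of > 10000 nM in this assay, at which 2 of the 3 values shown sit). Compound 4 `CC(C)n1nc(-c2cc(-c3ccc(F)cc3)on2)c2c(N)ncnc21` differs from compound 1 in one place: 4-fluorophenyl in place of cyclohexyl on an aromatic carbon. No measured pair shows what such a change does here, so the expectation rests only on the weak results of the three compounds shown. A modest gain is expected, an at least 2.0-fold lower number from compound 1 to compound 4 (0.30 log units; that floor lies within the scatter), while a second limit remains quite possible. Compound 4 is therefore estimated at 5000 nM, expected to fall between 1500 nM and 20000 nM.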

Compound 4, concentration for 50% growth inhibition: > 10000 nM
Compound 4: a limit, no number; the forecaster's own chance of this, stated with the estimate: 40%; at least 2.0-fold (0.30 log units) between middle value and limit.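

Compound 1 and compound 4 each give only a limit in this assay, so no step between them can be read: the limit of > 10000 nM in this assay, at which 3 of the 4 values shown sit.
Going by these compounds, whether 4-fluorophenyl in place of cyclohexyl changes growth inhibition at all remains open.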